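Methyl to nitro on the pendant phenyl: expected effect

This account rests on a few compounds, and the source may have more. Where it says the series, first, only, none or still open, it means among the compounds named here.

The series shares one core; compound 1 `Oc1ccccc1/C=N/c1nnc(SCc2nnc(-c3ccccc3Cl)o2)s1`, compound 2 `Oc1ccccc1/C=N/c1nnc(SCc2nnc(-c3ccccc3Br)o2)s1` and compound 3 `Cc1cccc(-c2nnc(CSc3nnc(/N=C/c4ccccc4O)s3)o2)c1` differ only in the substituted phenyl group. In a functional assay on SMMC-7721 cells (Homo sapiens) for inhibition, read by CCK-8 assay (on this read-out higher numbers stand for weaker inhibition and lower numbers for stronger inhibition), compound 1 gives 31800 nM, compound 2 gives 6780 nM and compound 3 gives 4550 nM. Compound 3 thus holds the lowest of the three numbers, but its gap to compound 2 is within the scatter (a 1.5-fold lower number from compound 2 to compound 3 (0.17 log units; within the scatter)), whereas its gap to compound 1 is beyond it (a 7.0-fold lower number from compound 1 to compound 3 (0.84 log units; beyond the scatter)); the halogen exchange a 4.7-fold lower number from compound 1 to compound 2 (0.67 log units; beyond the scatter) is also beyond the scatter.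

Compound 4 `O=[N+]([O-])c1cccc(-c2nnc(CSc3nnc(/N=C/c4ccccc4O)s3)o2)c1` is not yet measured. Its change from compound 3 is nitro in place of methyl on an aromatic carbon. Within the data shown here, no measured step exchanges one group for another at that place on the phenyl ring: the two steps that reach compound 3 both replace a 2-chlorophenyl or a 2-bromophenyl by 3-methylphenyl and move the number down, modestly in a 7.0-fold lower number from compound 1 to compound 3 (0.84 log units; beyond the scatter) and within the scatter in a 1.5-fold lower number from compound 2 to compound 3 (0.17 log units; within the scatter), and neither shows how a nitro group behaves. The direction of the step in this assay is therefore open; with nothing pointing to a large change, a step within the scatter is expected, a 1.3-fold higher number from compound 3 to compound 4 (0.12 log units; within the scatter). Compound 4 is estimated at 6000 nM, with a range from 1500 nM to 25000 nM.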

Compound 4, half-maximal inhibitory concentration: 15700 nM
Beside the measured number, compound 4's estimate is 2.6-fold (0.42 log units) below it, within the range that was stated.
By their numbers in this assay, from the lowest: compounds 3 and 2 (each within the scatter of the next); then compound 4; then compound 1.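

In this assay, among these compounds, the exchange of nitro for methyl is the first comparison of two groups at one place on the phenyl ring, and it gives a 3.5-fold higher number from compound 3 to compound 4 (0.54 log units; beyond the scatter), so this place is sensitive to the group it carries. Among the compounds shown here, the 3-nitrophenyl group also separates compounds that the earlier steps could not order by ring pattern alone: against the 2-halophenyl compounds it gives a 2.3-fold higher number from compound 2 to compound 4 (0.36 log units; beyond the scatter) and a 2.0-fold lower number from compound 1 to compound 4 (0.31 log units; beyond the scatter), which leaves compound 4 between the two halogen compounds, while compound 3 stays within the scatter of compound 2. Nothing measured in this series accounts for the rise from methyl to nitro.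

Going by these compounds, with only methyl and nitro at this place, it remains open whether other groups there, such as an amine, a methoxy group or a carboxylic acid, would stay close to compound 3 or move towards compound 4. On these data alone, it is equally open whether chloro or bromo at this same place would track compound 1 and compound 2, which would separate the identity of the halogen from where it sits on the ring.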